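The source may hold more compounds than are shown below. What is called first, only, known or untested is meant among the compounds shown, and "the series" means these compounds.

Compound 1 `ClCc1ccccc1Cn1cnc2c(Cl)nc(Cl)nc21` and compound 2 `ClCc1cccc(Cn2cnc3c(Cl)nc(Cl)nc32)c1` are built from the same atoms joined differently; the difference between the two cores is not broken down here. In a functional assay on SK-MEL-28 cells (Homo sapiens) for cytotoxicity, read by sulforhodamine B assay, with a stated time of 48 h (a lower number here means a stronger inhibitor of growth, a higher number a weaker inhibitor of growth), compound 1 gives 1230 nM, and compound 2 gives 2340 nM, a gap that lies within the usual scatter. Compound 3 `Nc1nc(Cl)c2ncn(Cc3ccccc3CCl)c2n1` carries the change (amino in place of chloro on an aromatic carbon), and in this assay compound 3 gives 4790 nM, so the step of a 3.9-fold higher number from compound 1 to compound 3 (0.59 log units; beyond the scatter). Compound 4 `Nc1nc(Cl)c2ncn(Cc3cccc(CCl)c3)c2n1` carries the same change on the core of compound 2, namely (amino in place of chloro on an aromatic carbon). Because the step of a 3.9-fold higher number from compound 1 to compound 3 (0.59 log units; beyond the scatter) was modest and beyond the scatter, a step of similar size is expected for compound 4, a 3.4-fold higher number from compound 2 to compound 4 (0.53 log units; beyond the scatter), in this assay. Compound 4 is therefore estimated at 8000 nM, expected to fall between 3500 nM and 18000 nM.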

Compound 4, concentration for 50% growth inhibition: 4460 nM
For compound 4 the middle estimate is 1.8-fold (0.25 log units) above the measured one; low and high end bracket the measured number.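

In this assay, amino in place of chloro on an aromatic carbon gives a 1.9-fold higher number from compound 2 to compound 4 (0.28 log units; within the scatter). Set beside the earlier step on the core of compound 1, the size of the change cannot be told apart between the two cores: the same change on two cores in this assay, a 3.9-fold higher number (0.59 log units; beyond the scatter) from compound 1 to compound 3 and a 1.9-fold higher number (0.28 log units; within the scatter) from compound 2 to compound 4, 2.0-fold (0.31 log units) apart, within the scatter of two such steps. Within the data shown here, this shows that the two steps agree on these two cores, although only the step to compound 3 stands clear of the scatter by itself. It does not show that the step would hold on any further core, and two pairs are too few to establish a rule for the series.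

The compounds shown leave open how a methoxy group or a methylamino group at the same place would compare with amino and chloro. They also leave open whether a longer chain in place of the chloromethyl group would alter the size of the step.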